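Ethoxycarbonyl to carboxy on compound 1

This account rests on a few compounds, and the source may have more. Where it says the series, first, only, none or still open, it means among the compounds named here.

In a functional assay on a cell-free system (plasma, Oryctolagus cuniculus) for inhibition, with stated times of 5 min, 1 min and 6 min (on this read-out lower numbers stand for stronger inhibition and higher numbers for weaker inhibition), compound 1 (`CCOC(=O)c1c(C)nc(-c2cccc(C#N)c2)n1OC`) gives 9130 nM, and compound 3 (`CCOC(=O)c1c(C)nc(-c2cccc(C#N)c2)n1OCc1ccccc1`) gives 5930 nM, the two lying within the scatter of each other. Compound 2 (`CCOC(=O)c1c(C)nc(-c2ccccc2)n1OC`) is reported only as a limit, > 30000 nM.

Compound 4 (`COn1c(-c2cccc(C#N)c2)nc(C)c1C(=O)O`) differs from compound 1 as follows: hydrogen in place of ethyl on an oxygen next to a carbonyl group. The measured steps lie elsewhere on the molecule: an at least 3.2-fold higher number from compound 1 to compound 2 (0.51 log units; beyond the scatter) with hydrogen in place of cyano, and a 1.5-fold lower number from compound 1 to compound 3 (0.19 log units; within the scatter) with phenyl in place of hydrogen. Neither touches the ethoxycarbonyl, so the size of this change is only loosely bounded. The expected step, with much uncertainty, is an 18-fold lower number from compound 1 to compound 4 (1.26 log units; beyond the scatter). Compound 4 is estimated at 500 nM, with an expected range of 30 nM to 9000 nM.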

Compound 4, half-maximal inhibitory concentration: 7990 nM
Compound 4: the middle estimate sits 16-fold (1.20 log units) below what was measured; low and high end bracket the measured number.
By their numbers in this assay, from the lowest: compounds 3, 4 and 1 (each within the scatter of the next). At a limit, above all of these: compound 2.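

Exchanging ethoxycarbonyl for carboxy in this assay gives a 1.1-fold lower number from compound 1 to compound 4 (0.06 log units; within the scatter), so the two groups are not told apart at this position. Among these compounds, the nitrile remains the only place with a step beyond the scatter, an at least 3.2-fold higher number from compound 1 to compound 2 (0.51 log units; beyond the scatter), and that step rests on a limit for compound 2. Nothing measured here accounts for the result.

Going by these compounds, whether an amide or a longer ester at this position would depart from these two groups remains open. Also open, on these data alone, is whether carboxy would read the same on the core of compound 3.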